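Working notes: trimethoxyphenyl at the five-membered ring carbon

The source may hold more compounds than are shown below. What is called first, only, known or untested is meant among the compounds shown, and "the series" means these compounds.

Compound 1 `COc1cc(/C=C/C(=O)c2cccc(-n3cc(-c4ccccc4)[nH]c3=O)c2)ccc1O` gives 1950 nM in a functional assay on NCI-H460 cells (Homo sapiens) for inhibition; a lower number here means a stronger inhibitor of growth, a higher number a weaker inhibitor of growth.
Compound 2 `COc1ccc(-c2cn(-c3cccc(C(=O)/C=C/c4cc(OC)c(OC)c(OC)c4)c3)c(=O)[nH]2)cc1` gives 1560 nM in this assay.
Compound 3 `COc1ccc(-c2cn(-c3cccc(C(=O)/C=C/c4ccc(O)c(OC)c4)c3)c(=O)[nH]2)cc1` gives 3230 nM in this assay.

Compound 2 has the lowest number of the three, but only compound 3 lies beyond the scatter from it: a 2.1-fold higher number from compound 2 to compound 3 (0.32 log units; beyond the scatter). Compound 1 sits within the scatter of compound 2, so no order between those two can be read.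

Compound 4 `COc1cc(/C=C/C(=O)c2cccc(-n3cc(-c4cc(OC)c(OC)c(OC)c4)[nH]c3=O)c2)cc(OC)c1OC` is not yet measured. It differs from compound 2 in one place: 3,4,5-trimethoxyphenyl in place of 4-methoxyphenyl on an aromatic carbon.

Among the measured compounds shown here, no measured step makes this exact exchange. The nearest comparison is a 1.7-fold higher number from compound 1 to compound 3 (0.22 log units; within the scatter), a methoxy added on an aromatic carbon of this same ring, which stayed within the scatter. The other step, a 2.1-fold higher number from compound 2 to compound 3 (0.32 log units; beyond the scatter), concerns the aryl on the double-bonded chain carbon, not the ring in question, and was modest. Taken together, no step beyond the scatter is expected in this assay for compound 4, in either direction, with a slight lean toward a higher number given where compound 3 stands.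

Compound 4 is therefore estimated at 1800 nM, with an expected range of 800 nM to 4000 nM. The step this estimate implies, a 1.2-fold higher number from compound 2 to compound 4 (0.06 log units; within the scatter), is expected to fall within the scatter.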

Compound 4, concentration for 50% growth inhibition: 1730 nM
Compound 4: the middle estimate sits 1.0-fold (0.02 log units) above what was measured, and the stated range covers the measured number.
By their numbers in this assay, from the lowest: compounds 2, 4, 1 and 3 (each within the scatter of the next, the first and the last beyond it).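

In this assay, putting 3,4,5-trimethoxyphenyl in place of 4-methoxyphenyl on the aromatic carbon of the five-membered aromatic ring gives a 1.1-fold higher number from compound 2 to compound 4 (0.04 log units; within the scatter), so this position accepts the added methoxy groups of the bigger aryl without a readable shift in growth inhibition. The earlier step at this ring carbon, a 1.7-fold higher number from compound 1 to compound 3 (0.22 log units; within the scatter), added a single methoxy with 4-hydroxy-3-methoxyphenyl on the chain; the new step extends the same flat reading to a larger exchange, with 3,4,5-trimethoxyphenyl on the chain. No measurement at hand offers an explanation for this flat response.

The compounds shown leave open whether this position stays flat once the aryl carries something other than methoxy, such as an amine or a carboxylic acid, or once the aryl gives way to a longer alkyl chain. Also open, as far as these compounds go, is whether 3,4,5-trimethoxyphenyl at this ring carbon reads the same when 4-hydroxy-3-methoxyphenyl stands on the chain, since the two exchanges at this position were each read with a different chain aryl.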